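Swapping Methoxy for Methyl on a Weakly Active Core

A few compounds are considered here, and "the series" means these few. Any claim that something is new, unique, unknown or untested is made for them only; others in the source may bear on it.

Compound 1 `C=C1C(=O)[C@]23C[C@@]1(O)CC[C@H]2c1ccc(O)c(C)c1[C@@H]3Cn1cc(-c2ccc(C)cc2)nn1` gives 830 nM in a functional assay on HL-60 cells (Homo sapiens) for cytotoxicity, read by MTT assay, with a stated time of 4 days; a higher number here means a weaker inhibitor, a lower number a stronger inhibitor.
Compound 2 `C=C1C(=O)[C@]23C[C@@]1(O)CC[C@H]2c1ccc(O)c(C)c1[C@@H]3Cn1cc(-c2ccc(OC)cc2)nn1` gives 1150 nM in this assay.
Compound 3 `C=C1C[C@]23C[C@@]1(O)CC[C@H]2c1ccc(O)c(C)c1[C@@H]3Cn1cc(-c2ccc(OC)cc2)nn1` gives only a limit of the assay, > 20000 nM, in this assay.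

Compounds 1 and 2 share one core and differ only at the phenyl ring; the change from compound 2 to compound 1 is methyl in place of methoxy on an aromatic carbon and it made a step of a 1.4-fold lower number from compound 2 to compound 1 (0.14 log units; within the scatter), so the two values tell the same story. Compound 3 carries a different core, and the difference between the two cores is not broken down here. Compound 3 sits at the limit of > 20000 nM in this assay, at which 1 of the 3 values shown sits, and gives no number at all.

Compound 4 `C=C1C[C@]23C[C@@]1(O)CC[C@H]2c1ccc(O)c(C)c1[C@@H]3Cn1cc(-c2ccc(C)cc2)nn1` is still to be measured in this assay. It differs from compound 3 by methyl in place of methoxy on an aromatic carbon, which is the same change, at the same place, as between compound 2 and compound 1. Because the earlier step was a 1.4-fold lower number from compound 2 to compound 1 (0.14 log units; within the scatter), and because the value of compound 3 sits at the limit (the limit of > 20000 nM in this assay, at which 1 of the 3 values shown sits), compound 4 is expected to remain at or beyond that limit. The step from compound 3 to compound 4 is expected to be a number no higher from compound 3 to compound 4 (the limit leaves the size open). Compound 4 is expected to give about 20000 nM, most likely between 8000 nM and 60000 nM, with a good chance that only a limit is reported once more.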

Compound 4, half-maximal inhibitory concentration: > 20000 nM
Compound 4: no number, only a limit (the forecaster's own chance of this, stated with the estimate: 70%); the middle value lies on the limit itself.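

Compound 3 and compound 4 both stop at a limit of this assay and give no number, so the step between them cannot be read: the limit of > 20000 nM in this assay, at which 2 of the 4 values shown sit.

The compounds shown leave open how far beyond the limit compound 3 and compound 4 lie, and whether methyl in place of methoxy on an aromatic carbon matters on their core.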